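The compounds below may be only part of what the source reports. "The series", "measured", "known", "first", "only" and "open" are said of these compounds alone.

In a functional assay on ACHN cells (Homo sapiens) (on this read-out lower numbers stand for stronger inhibition of growth and higher numbers for weaker inhibition of growth), compound 1 `O=S(=O)(/C=C/c1ccccc1)Cc1ccc(Nc2ncnc3ccccc23)cc1` gives 58000 nM, and compound 2 `COc1cc2ncnc(Nc3ccc(CS(=O)(=O)/C=C/c4ccc(Cl)cc4Cl)cc3)c2cc1OC` gives 15000 nM. Compound 3 `COc1cc2ncnc(Nc3ccc(CS(=O)(=O)/C=C/c4ccc(F)cc4)cc3)c2cc1OC` gives > 100000 nM, which is a limit and not a number; it stands at the limit of > 100000 nM in this assay, at which 1 of the 3 values shown sits.

Compound 4 `COc1cc2ncnc(Nc3ccc(CS(=O)(=O)/C=C/c4ccc(Br)cc4)cc3)c2cc1OC` changes one group: bromo in place of fluoro on an aromatic carbon, with bromo in place of fluoro on an aromatic carbon. Among the measured compounds shown here, the one measured step that bears on this is an at least 6.6-fold higher number from compound 2 to compound 3 (0.82 log units; beyond the scatter), which lies beyond the scatter and also involves the halogens on this ring. Since that step rose on going to the 4-fluorophenyl group, a move away from fluoro is expected to lower the number, perhaps by a similar size. The expected change is an at least 2.5-fold lower number from compound 3 to compound 4 (0.39 log units; beyond the scatter). For compound 4 the estimate is 40000 nM, with an expected range of 12000 nM to 100000 nM.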

Compound 4, concentration for 50% growth inhibition: 4000 nM
The estimate for compound 4 lay 10-fold (1.00 log units) above the measured number; measured number below the stated range.
By their numbers in this assay, from the lowest: compound 4; then compound 2; then compound 1. At a limit, above all of these: compound 3.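

On this ring, the halogen para to a large group strongly affects the read-out: in this assay, bromo in place of fluoro gives an at least 25-fold lower number from compound 3 to compound 4 (1.39 log units; beyond the scatter). The value for compound 3 is a limit and not a number: the limit of > 100000 nM in this assay, at which 1 of the 4 values shown sits. A single bromo also outperforms the two chloro groups, with a 3.8-fold lower number from compound 2 to compound 4 (0.57 log units; beyond the scatter), so among these compounds, more halogen atoms do not by themselves give the lower number.

The compounds shown leave open how an amine or a nitrile would read at this place. They also leave open whether bromo would give a similar drop on the core of compound 1.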